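Hydroxamate series: chain terminus swap at the amine nitrogen

The source may report more compounds than this note shows. Statements on the series, on what has been measured and on what is new or still open speak of the compounds shown alone.

Measured compounds in a functional assay on A549 cells (Homo sapiens) for antiproliferative activity, read by MTT assay, with a stated time of 48 h; on this read-out higher numbers stand for weaker inhibition of growth and lower numbers for stronger inhibition of growth:
- compound 1 `Cc1ccc(OCCCCN(Cc2ccc(C(=O)NO)cc2)c2ncc(-c3ccc(C)cc3)s2)cc1` gives 8630 nM
- compound 2 `CCCCCCN(Cc1ccc(C(=O)NO)cc1)c1ncc(-c2ccc(C)cc2)s1` gives 3710 nM
- compound 3 `Cc1ccc(-c2cnc(N(Cc3ccc(C(=O)NO)cc3)CC(C)C)s2)cc1` gives 20400 nM

Compound 2 stands lowest of the three numbers in this assay, and both of its steps to the other compounds lie beyond the scatter: a 5.5-fold higher number from compound 2 to compound 3 (0.74 log units; beyond the scatter) and, seen from the aryloxy-terminated chain, a 2.3-fold lower number from compound 1 to compound 2 (0.37 log units; beyond the scatter). It is therefore the strongest inhibitor of growth among the measured compounds. Compound 3, with the shortest branch on the nitrogen, gives the highest number, and the step of a 2.4-fold higher number from compound 1 to compound 3 (0.37 log units; beyond the scatter) places it above compound 1 as well.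

Compound 4 `Cc1ccc(-c2cnc(N(CCCOc3ccccc3)Cc3ccc(C(=O)NO)cc3)s2)cc1` is not yet measured. Relative to compound 2 the change is phenoxy in place of propyl on a saturated chain carbon, three bonds along the chain from a nitrogen on an aromatic ring. Its chain is one carbon shorter than that of compound 1 and carries no methyl on the aromatic ring, so it sits structurally between compound 1 and compound 2. The step that bears most directly on it is a 2.3-fold lower number from compound 1 to compound 2 (0.37 log units; beyond the scatter), a modest step in favour of the plain chain; the step of a 5.5-fold higher number from compound 2 to compound 3 (0.74 log units; beyond the scatter) shows that shortening the chain further also raises the number. On that basis a modest upward step is expected for compound 4, close to the reverse of the step from compound 1 to compound 2, giving an expected 1.8-fold higher number from compound 2 to compound 4 (0.24 log units; within the scatter). Compound 4 is estimated at 6500 nM, with a range from 3000 nM to 14000 nM.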

Compound 4, concentration for 50% growth inhibition: 2530 nM
Compound 4: middle estimate off by 2.6-fold (0.41 log units), on the high side, and the stated range ends above it.
By their numbers in this assay, from the lowest: compounds 4 and 2 (each within the scatter of the next); then compound 1; then compound 3.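

Notes on the chain terminus: in this assay the step of a 1.5-fold lower number from compound 2 to compound 4 (0.17 log units; within the scatter) gives no separation, so at this place, three bonds along the chain from a nitrogen on an aromatic ring, phenoxy and propyl cannot be told apart, even though the entering group brings an aromatic ring and a hydrogen-bond acceptor that propyl lacks. An aryl ether terminus therefore does not in itself carry the rise seen with compound 1, since the step of a 3.4-fold lower number from compound 1 to compound 4 (0.53 log units; beyond the scatter) lies beyond the scatter and shows that replacing (4-methylphenoxy)methyl with phenoxy at this place matters. The step of an 8.1-fold lower number from compound 3 to compound 4 (0.91 log units; beyond the scatter) is the largest one in the set so far and adds a second long chain, alongside the hexyl of compound 2, that stands clearly apart from the isopropyl-ended compound 3.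

No supporting measurement is available to account for any of these steps. Still open, as far as these compounds go, is how a terminal amine or a carboxylic acid would read in place of phenoxy at this place, and whether a longer chain ending in an unsubstituted phenoxy would follow compound 4 or compound 1.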